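This account rests on a few compounds, and the source may have more. Where it says the series, first, only, none or still open, it means among the compounds named here.

Going by the values given here, compound 2 `Cc1ccc(NC(=O)Nc2cc(/C(=N/O)Nc3ccc(F)c(Br)c3)ccc2N(CC(C)C)CC(C)C)cc1` gives 760 nM in an assay on HeLa cells for inhibition of Indoleamine 2,3-dioxygenase 1 (Homo sapiens) (on this read-out lower numbers stand for stronger inhibition and higher numbers for weaker inhibition), the lowest of the two numbers measured so far; compound 1 `CCCCNC(=O)Nc1cc(/C(=N/O)Nc2ccc(F)c(Br)c2)ccc1N(CC(C)C)CC(C)C` gives 3110 nM in this assay. Among the compounds with values here, the one measured step, a 4.1-fold lower number from compound 1 to compound 2 (0.61 log units; beyond the scatter), concerns the group on the amide-type nitrogen only. Compound 3 `Cc1ccc(NC(=O)Nc2cc(/C(=N/O)Nc3ccc(C)cc3)ccc2N(CC(C)C)CC(C)C)cc1` keeps that group unchanged and differs from compound 2 at the other end of the molecule: 4-methylphenyl in place of 3-bromo-4-fluorophenyl on an amine nitrogen. Within the data shown here, no measured step touches this position, so the step from compound 1 to compound 2 offers no direct guide, beyond showing that this assay does respond to changes on the outer groups of the shared core. With nothing measured at this position, the expected step of a 2.0-fold higher number from compound 2 to compound 3 (0.30 log units; within the scatter) is a modest rise in the number, and the range is kept wide. Compound 3 is therefore estimated at 1500 nM, with a range from 400 nM to 6000 nM.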

Compound 3, half-maximal inhibitory concentration: 1340 nM
For compound 3 the middle estimate is 1.1-fold (0.05 log units) above the measured one; the measured number falls inside the stated range.
By their numbers in this assay, from the lowest: compounds 2 and 3 (each within the scatter of the next); then compound 1.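

Putting 4-methylphenyl in place of 3-bromo-4-fluorophenyl on the amine nitrogen gives a 1.8-fold higher number from compound 2 to compound 3 (0.25 log units; within the scatter) in this assay, so this pair of groups is not told apart at this position. Within compounds 2 and 3, then, a number in this range does not depend on the bromine or the fluorine, as a ring carrying only a methyl group serves as well. Nothing available explains why these two groups read alike.

Still open, going by these compounds, is whether an aromatic ring is needed on this nitrogen at all, as a cyclohexyl group or a butyl chain there would show. Also open, on these data alone, is how the position responds to a ring carrying an amine or a carboxylic acid, and whether such a change would move the number beyond the scatter.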